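Sulfoxide to methylsulfonyl on two triazole cores

This account rests on a few compounds, and the source may have more. Where it says the series, first, only, none or still open, it means among the compounds named here.

Compound 1 `Cn1c(-c2cccc3ccccc23)nnc1[S+](C)[O-]` carries a sulfoxide on its core. In a functional assay on the whole organism for antagonist activity, with Mus musculus as the target (on this read-out higher numbers stand for an effect only at larger amounts of compound and lower numbers for an effect already at smaller amounts), compound 1 gives a limit of the assay, > 200 mg/kg. Compound 2 `Cn1c(-c2cccc3ccccc23)nnc1S(C)(=O)=O` differs by a group of 4 heavy atoms (1 carbon, 2 oxygen, 1 sulfur; no ring) in place of a group of 3 heavy atoms (1 carbon, 1 oxygen, 1 sulfur; no ring), on an aromatic carbon. In this assay compound 2 also gives only a limit, > 200 mg/kg. The resulting step, a step that the two limits leave unreadable from compound 1 to compound 2, cannot be read; both values sit at the limit of > 200 mg/kg in this assay, at which 3 of the 3 values shown sit. Compound 3 `Cn1nc(-c2ccccc2)nc1[S+](C)[O-]` has a second core; the difference between the two cores is not broken down here. In this assay compound 3 gives a limit, > 200 mg/kg. Compound 4 `Cn1nc(-c2ccccc2)nc1S(C)(=O)=O` is not yet measured and differs from compound 3 by a group of 4 heavy atoms (1 carbon, 2 oxygen, 1 sulfur; no ring) in place of a group of 3 heavy atoms (1 carbon, 1 oxygen, 1 sulfur; no ring), on an aromatic carbon, the same kind of change as that from compound 1 to compound 2. The step that the limit leaves unreadable from compound 3 to compound 4 is expected to stay unreadable, since compound 3 sits at the limit of > 200 mg/kg in this assay, at which 3 of the 3 values shown sit. Compound 4 is estimated at 300 mg/kg in this assay, within 120 mg/kg to 1000 mg/kg, most likely again reported only as a limit.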

Compound 4, dose for half-maximal effect: > 200 mg/kg
Compound 4 gave a limit, no number; the forecaster's own chance of this, stated with the estimate: 85%; the middle value does not contradict the limit.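

The step from compound 3 to compound 4 cannot be read, because both compounds give only a limit of the assay: the limit of > 200 mg/kg in this assay, at which 4 of the 4 values shown sit.

Going by these compounds, how the sulfoxide and methylsulfonyl compare on either core remains open, as does the dose at which any of the four compounds would show an effect.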